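The compounds below may be only part of what the source reports. "The series", "measured", "known", "first", "only" and "open" are said of these compounds alone.

Three compounds built on one shared core differ only in the group attached to a carbonyl carbon whose other neighbour is an amide-type nitrogen. Compound 1 `CCC(=O)N(C)c1ccc2[nH]c(-c3n[nH]c4ccccc34)cc2n1` carries an ethyl group there, compound 2 `CN(C(=O)C(C)(C)C)c1ccc2[nH]c(-c3n[nH]c4ccccc34)cc2n1` a tert-butyl group, and compound 3 `CN(C(=O)c1ccc(Br)cc1)c1ccc2[nH]c(-c3n[nH]c4ccccc34)cc2n1` a 4-bromophenyl group. In a functional assay on HCT-116 cells (Homo sapiens) for antiproliferative activity, read by MTT assay, with a stated time of 72 h (a lower number here means a stronger inhibitor, a higher number a weaker inhibitor), compound 1 gives 10800 nM, compound 2 gives 18000 nM, and compound 3 gives 6110 nM. Compound 2 thus shows the highest of the three numbers; its gap to compound 1, a 1.7-fold higher number from compound 1 to compound 2 (0.22 log units; within the scatter), lies within the scatter, whereas a 2.9-fold lower number from compound 2 to compound 3 (0.47 log units; beyond the scatter) is a modest step beyond it.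

Compound 4 `CN(C(=O)c1ccco1)c1ccc2[nH]c(-c3n[nH]c4ccccc34)cc2n1` is the next member, and the change from compound 2 reads (furan-2-yl in place of tert-butyl on a carbonyl carbon). Among the measured compounds shown here, the one measured step that resembles it is the exchange of tert-butyl for a ring on the same carbonyl carbon, a 2.9-fold lower number from compound 2 to compound 3 (0.47 log units; beyond the scatter); the related exchange a 1.8-fold lower number from compound 1 to compound 3 (0.25 log units; within the scatter) stayed within the scatter. A ring again replaces the tert-butyl, so a modest lowering is the most that these steps support. Compound 4 is therefore expected to give about 7500 nM in this assay, with a range from 3000 nM to 19000 nM, which would mean an estimated step of a 2.4-fold lower number from compound 2 to compound 4 (0.38 log units; beyond the scatter).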

Compound 4, half-maximal inhibitory concentration: 30000 nM
Beside the measured number, compound 4's estimate is 4.0-fold (0.60 log units) below it; measured number above the stated range.
By their numbers in this assay, from the lowest: compounds 3, 1, 2 and 4 (each within the scatter of the next, the first and the last beyond it).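

In this assay, carrying a ring on the carbonyl carbon does not by itself lower the number: furan-2-yl and 4-bromophenyl are both aromatic rings, yet a 4.9-fold higher number from compound 3 to compound 4 (0.69 log units; beyond the scatter) lies beyond the scatter, so the identity of the ring matters. Among the compounds shown here, the earlier compounds could not show this, since compound 3 was the only one with a ring. The furan-2-yl group also cannot be told apart from the ring-free tert-butyl group, with a 1.7-fold higher number from compound 2 to compound 4 (0.22 log units; within the scatter) staying within the scatter, while the step from the small ethyl group, a 2.8-fold higher number from compound 1 to compound 4 (0.44 log units; beyond the scatter), is modest but beyond it, so compound 4 sits with compound 2 at the weak end of this short series.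

From the compounds shown here alone, it remains open whether the gap between compound 3 and compound 4 comes from the phenyl ring or from its bromine, which a plain phenyl group or a pyridine ring on the same carbonyl carbon could help to separate. Nothing shown here gives an independent measurement that would explain why these groups differ.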